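Anilino to benzylamino on the shared core

The source may report more compounds than this note shows. Statements on the series, on what has been measured and on what is new or still open speak of the compounds shown alone.

Measured so far in a functional assay on HeLa cells (Homo sapiens) for antiproliferative activity, read by CCK-8 assay, with a stated time of 72 h; on this read-out lower numbers stand for stronger inhibition and higher numbers for weaker inhibition:
- compound 1 `Cc1ccc(Nc2nc(Cl)nc3c2ncn3Cc2ccc(C(=O)Nc3ccccc3N)cc2)cc1` gives 1050 nM
- compound 2 `Nc1ccccc1NC(=O)c1ccc(Cn2cnc3c(Nc4ccccc4)nc(Cl)nc32)cc1` gives 2920 nM

Of these two numbers, compound 2 has the higher, and compound 1 is its nearest neighbour. Compound 3 `Nc1ccccc1NC(=O)c1ccc(Cn2cnc3c(NCc4ccccc4)nc(Cl)nc32)cc1` carries benzyl in place of phenyl on a nitrogen on an aromatic ring, that is, anilino to benzylamino (benzyl in place of phenyl on a nitrogen on an aromatic ring). For the measured compounds named here, no measured step tests this change directly. Going by the values given here, the only guide to size is a 2.8-fold higher number from compound 1 to compound 2 (0.44 log units; beyond the scatter) as a modest step, with hydrogen in place of methyl on an aromatic carbon. A step of similar modest size is therefore expected in this assay and, on thin evidence, towards a higher number. The estimated step is a 1.2-fold higher number from compound 2 to compound 3 (0.08 log units; within the scatter) for now. Compound 3 is estimated at 3500 nM with 1200 nM to 10000 nM as its expected range.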

Compound 3, half-maximal inhibitory concentration: 6770 nM
The estimate for compound 3 lay 1.9-fold (0.29 log units) below the measured number, within the range that was stated.
By their numbers in this assay, from the lowest: compound 1; then compound 2; then compound 3.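

In this assay the nitrogen on the shared core now shows sensitivity to the group itself as well as to a substituent on its ring, with anilino to benzylamino giving a 2.3-fold higher number from compound 2 to compound 3 (0.37 log units; beyond the scatter) as a step beyond the scatter. Benzyl in place of 4-methylphenyl gives a 6.4-fold higher number from compound 1 to compound 3 (0.81 log units; beyond the scatter) and is the largest step in the series so far. Among these three compounds, both with the aromatic ring placed directly on the nitrogen give lower numbers than the benzyl compound 3, and none goes against that order.

Going by these compounds, it remains open whether 4-methylbenzyl would regain what methyl gained on the phenyl ring, and how a longer chain such as 2-phenylethyl or a carboxylic acid on the ring would read. No evidence at hand accounts for these differences.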